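A few compounds are considered here, and "the series" means these few. Any claim that something is new, unique, unknown or untested is made for them only; others in the source may bear on it.

Working notes on the series around compound 1 `NC(=O)c1ccc(Cn2ncc3c(Nc4ccc(OC(F)(F)F)cc4)ncnc32)cc1`. In an ADME assay on BaF3 cells (Mus musculus) for cytotoxicity (on this read-out lower numbers stand for an effect already at smaller amounts and higher numbers for an effect only at larger amounts of compound), compound 1 gives > 10000 nM, which is a limit of the assay and not a number. Compound 2 `FC(F)(F)Oc1ccc(Nc2ncnc3nn(C4CCCCC4)cc23)cc1` also stands at a limit in this assay, with > 10000 nM. Compound 3 `FC(F)(F)Oc1ccc(Nc2cc(-c3cn[nH]c3)ncn2)cc1` likewise yields only a limit in this assay, > 10000 nM. Among the compounds with values here, the picture so far is uniform: the limit of > 10000 nM in this assay, at which 3 of the 3 values shown sit, so none of the measured compounds has a numerical read-out that would place compound 1 above or below another.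

Compound 4 `CCCn1ncc2c(Nc3ccc(OC(F)(F)F)cc3)ncnc21` has not yet been measured in this assay. It differs from compound 1 in one place: ethyl in place of 4-carbamoylphenyl on a saturated chain carbon bound to an aromatic nitrogen. Within the data shown here, no measured step between two compounds exists, so the size of the effect of this change cannot be read from the data at hand. Given (the limit of > 10000 nM in this assay, at which 3 of the 3 values shown sit), the expectation is that the step that the limit leaves unreadable from compound 1 to compound 4 will be no larger than the scatter and that the read-out will most probably again come back as a limit rather than a number. For compound 4 the estimate in this assay is 15000 nM, within 5000 nM to 50000 nM.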

Compound 4, half-maximal effective concentration: 6600 nM
For compound 4 the middle estimate is 2.3-fold (0.36 log units) above the measured one; measured number inside the range.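

Within the data shown here, compound 4 is the first compound to give a number rather than a limit in this assay, at 6600 nM. Ethyl in place of 4-carbamoylphenyl on a saturated chain carbon bound to an aromatic nitrogen comes with an at least 1.5-fold lower number from compound 1 to compound 4 (0.18 log units; that floor lies within the scatter), so this position is the first place in the series where the read-out of this assay has moved off the limit, yet the printed floor of the step does not by itself establish a change beyond the scatter. The remaining compounds offer no second number against which compound 4 could be placed: the limit of > 10000 nM in this assay, at which 3 of the 4 values shown sit.

On these data alone, whether a longer chain such as butyl, a smaller group such as methyl, or an amine at the end of the propyl chain would also give a number in this assay stays open. As far as these compounds go, the value of compound 1 is a limit and not a number, so the full size of the step from the 4-carbamoylbenzyl group to the propyl group also stays open.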